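A few compounds are considered here, and "the series" means these few. Any claim that something is new, unique, unknown or untested is made for them only; others in the source may bear on it.

Working notes on the series. Compound 1 `N/C(=N\NC(=S)N1CCCC1)c1ccc(F)cn1` is the reference: in a functional assay on A-431 cells (Homo sapiens) for cytotoxicity, read by MTT assay, with a stated time of 72 h, tested at 1 uM (a higher number here means more inhibition of growth at the concentration tested, a lower number less inhibition of growth), compound 1 gives 50.7%, the highest of the two numbers in hand. Going by the values given here, the only other measured member, compound 2 `Cc1ccnc(/C(N)=N/NC(=S)N2CCSCC2)c1`, gives 34.6% in this assay, a gap beyond the usual scatter; compound 2 differs from compound 1 in more than one place, so its value says nothing direct about any single change. Compound 3 `N/C(=N\NC(=S)N1CCOCC1)c1ccc(F)cn1` is the next member, not yet tested. It differs from compound 1 in one place: morpholin-4-yl in place of pyrrolidin-1-yl on a thiocarbonyl carbon. Among the compounds with values here, no measured pair isolates this change, so the size of the step is open. Given only the two values available, the step from compound 1 to compound 3 in this assay is expected to be small, if anything downward, and possibly within the scatter: estimated a number 8.7 percentage points lower from compound 1 to compound 3 (within the scatter). For compound 3 in this assay the estimate is 42%, with a plausible range from 22% to 60%.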

Compound 3, percent growth inhibition at one concentration: 31.8%
Compound 3: the middle estimate sits 10.2 percentage points above what was measured; the range from low to high includes it.
By their numbers in this assay, from the lowest: compounds 3 and 2 (each within the scatter of the next); then compound 1.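

In this assay the step is a number 18.9 percentage points lower from compound 1 to compound 3 (beyond the scatter) and shows that the group on the thiocarbonyl carbon matters to growth inhibition with the rest of the core held fixed. Going by these compounds alone, this one swap changes the ring from five-membered to six-membered and also adds a ring oxygen with its hydrogen-bond acceptor, so the single step cannot divide the loss between those two differences. Nothing in hand bears on why the number falls with this change.

Piperidin-1-yl, a six-membered ring without the oxygen, would separate ring size from the oxygen, and its standing against compound 1 and compound 3 remains open. Also open, on these data alone, is whether a ring is needed at this place at all, which an open-chain dimethylamino group would test.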